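Replacing an amino group with phenyl on a compound measured for kinase inhibition

A few compounds are considered here, and "the series" means these few. Any claim that something is new, unique, unknown or untested is made for them only; others in the source may bear on it.

Measured compounds:
Compound 1 `Nc1c2c(=O)[nH]c(-c3ccccc3)cc2nn1-c1ccccc1` — 13%
Compound 2 `COc1ccccc1-c1cc2nn(-c3ccccc3)c(N)c2c(=O)[nH]1` — 7%
Compound 3 `Cc1cc2nc(N)nc(N)c2c(=O)[nH]1` — 6%

In an assay on isolated protein for inhibition of ribosomal protein S6 kinase alpha-5 (Homo sapiens), read by mobility shift assay, tested at 30 uM (a higher number here means more inhibition at the concentration tested (going by the name of the read-out), a lower number less inhibition), compound 1 gives 13%, compound 2 gives 7% and compound 3 gives 6%. Compound 3 therefore shows the lowest of the three numbers, but its gaps to compound 2 and to compound 1 both lie within the scatter of this assay, so no order can be read among them; all three give low numbers at the concentration tested.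

Compound 4 `Cc1cc2nc(-c3ccccc3)nc(N)c2c(=O)[nH]1` is not yet measured. It differs from compound 3 in one place: phenyl in place of amino on an aromatic carbon. The change sits on an aromatic carbon of a six-membered aromatic ring with two nitrogens, between the two ring nitrogen atoms.

Among the compounds with values here, the only measured step, a number 6 percentage points lower from compound 1 to compound 2 (within the scatter), concerns a different core and a methoxy group, so it does not bear on this change. Compounds 1 and 2 both carry phenyl groups and still give small numbers. With nothing pointing to a large effect, the expected step of a number 4 percentage points higher from compound 3 to compound 4 (within the scatter) is small, with no clear direction beyond the scatter. Compound 4 is therefore estimated at 10% in this assay, within 0% to 25%.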

Compound 4, a percentage reported as inhibition, at one concentration (the size of the read-out at that concentration, not a potency): 15%
Estimate against measurement, compound 4: 5 percentage points below; low and high end bracket the measured number.
By their numbers in this assay, from the lowest: compounds 3, 2, 1 and 4 (each within the scatter of the next).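

Within the data shown here, putting phenyl in place of amino on the aromatic carbon between two ring nitrogen atoms gives a number 9 percentage points higher from compound 3 to compound 4 (within the scatter) in this assay, which is the first direct reading of any change at this position. Here 1 heavy atom leaves and 6 heavy atoms enter, including a six-membered aromatic ring, while the hydrogen-bond donor and acceptor counted on amino leave, and even this large change in the group does not give a step beyond the usual scatter of the measurement. At this single test concentration, then, the amino group on this carbon is not shown to matter for the small inhibition of compound 3, and no other measurement here bears on why the step has this size.

The compounds shown leave open whether a different group on this carbon, such as a carboxylic acid, a morpholine ring or a longer alkyl chain, would move the number beyond the scatter. They also leave open whether any group here can lift the shared core of compound 3 and compound 4 from low inhibition to clear inhibition.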